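A few compounds are considered here, and "the series" means these few. Any claim that something is new, unique, unknown or untested is made for them only; others in the source may bear on it.

Compound 3 `Nc1nc(OCC(F)(F)F)c2ncn(/C=C3/CC3(CO)CO)c2n1` in an ADME assay on CCRF-HSB-2 cells (Homo sapiens) for cytotoxicity, with a stated time of 7 days (a higher number here means that more compound is tolerated, a lower number that less compound is tolerated), gives > 20000 nM, which is a limit of the assay and not a number. Compound 1 `CCCCSc1nc(N)nc2c1ncn2/C=C1/CC1(CO)CO` gives 89000 nM in this assay. Compound 2 `CCCNc1nc(N)nc2c1ncn2/C=C1/CC1(CO)CO` gives > 20000 nM in this assay, again a limit rather than a number. The step that the limit leaves unreadable from compound 1 to compound 2 and the step that the limit leaves unreadable from compound 1 to compound 3 cannot be sized from the values, nor can a step that the two limits leave unreadable from compound 2 to compound 3; the limit of > 20000 nM in this assay, at which 2 of the 3 values shown sit, marks where two of the three values sit. Compound 4 `CN(C)c1nc(N)nc2c1ncn2/C=C1/CC1(CO)CO` carries dimethylamino in place of 2,2,2-trifluoroethoxy on an aromatic carbon. For the measured compounds named here, no measured step at this place gives a readable size, so no step beyond the scatter in this assay is foreseen in either direction. Compound 4 is expected to give 60000 nM in this assay, within 20000 nM to 200000 nM. The expected step is a step that the limit leaves unreadable from compound 3 to compound 4.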

Compound 4, half-maximal cytotoxic concentration: > 20000 nM
Compound 4: a limit, no number; the forecaster's own chance of this, stated with the estimate: 70%; the middle value is on the limit's open side.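

In this assay, for the compounds shown here, compound 4 gives > 20000 nM, a limit of the assay and not a number, so no new step to compound 4 from compound 1, compound 2 or compound 3 can be read.

Whether compound 2, compound 3 and compound 4 differ from one another, or from compound 1, stays open: the limit of > 20000 nM in this assay, at which 3 of the 4 values shown sit.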